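Working notes: dimethylamino in place of acetyl

The source may report more compounds than this note shows. Statements on the series, on what has been measured and on what is new or still open speak of the compounds shown alone.

Measured so far:
compound 1 `COc1cc(C)cc(-c2c(-c3ccnc(-c4ccc(C(C)=O)cc4)c3)cnn2CC#N)c1`: > 100000 nM
compound 2 `Cc1cc(O)cc(-c2nn(CC#N)cc2-c2ccnc(-c3ccc(Oc4ccccc4)cc3)c2)c1`: 7120 nM
compound 3 `Cc1cc(O)cc(-c2nn(CC#N)cc2-c2ccnc(-c3ccc(N(C)C)cc3)c2)c1`: > 100000 nM

In a functional assay on Malme-3M cells (Homo sapiens) for inhibition, read by sulforhodamine B assay, with a stated time of 48 h (a higher number here means that more compound is tolerated, a lower number that less compound is tolerated), compound 1 sits at a limit of the assay, > 100000 nM, so no number is known for it. Compound 2 gives 7120 nM in this assay. Compound 3 also sits at a limit, > 100000 nM. Among the compounds with values here, the only step that can be sized, an at least 14-fold higher number from compound 2 to compound 3 (1.14 log units; beyond the scatter), ran from a number up to the limit, and that is the one step on which the present question rests.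

Compound 4 `COc1cc(C)cc(-c2c(-c3ccnc(-c4ccc(N(C)C)cc4)c3)cnn2CC#N)c1` differs from compound 1 in one place: dimethylamino in place of acetyl on an aromatic carbon. Compound 1 already stands at the limit, and the dimethylamino compound of the measured pair reached the same limit, as the limit of > 100000 nM in this assay, at which 2 of the 3 values shown sit, records. Compound 4 is therefore expected to stay at the limit too, with an expected step that the limit leaves unreadable from compound 1 to compound 4. The estimate for compound 4 is 150000 nM, with a range from 60000 nM to 400000 nM.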

Compound 4, concentration lethal to 50% of the cells: > 100000 nM
Compound 4: no number, only a limit; the forecaster's own chance of this, stated with the estimate: 85%; the middle value does not contradict the limit.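

No new step can be read between compound 1 and compound 4 in this assay, since both stand at the same limit rather than at a number: the limit of > 100000 nM in this assay, at which 3 of the 4 values shown sit. The compounds shown leave open whether dimethylamino in place of acetyl changes the lethal concentration at all.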